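Phenyl Added to Compound 2: Expected Potency

The source may report more compounds than this note shows. Statements on the series, on what has been measured and on what is new or still open speak of the compounds shown alone.

Compound 1 `O=c1c2ccccc2sn1C1CCCCC1` gives 55.5 nM in an assay on HeLa cells for inhibition of Monoglyceride lipase (Rattus norvegicus), read by LC-MS, with a stated time of 10 min; a higher number here means a weaker inhibitor, a lower number a stronger inhibitor.
Compound 2 `O=c1c2ccccc2sn1NCc1ccccc1` gives 19.5 nM in this assay.

Compound 2 stands lowest of the two numbers, and compound 1 gives a higher number in this assay, beyond the scatter. Compound 3 `O=c1c2ccccc2sn1NCc1ccc(-c2ccccc2)cc1` differs from compound 2 by phenyl in place of hydrogen on an aromatic carbon. Among the measured compounds shown here, no pair of measured compounds shows the effect of such a change, so the step is uncertain; a small move in this assay, perhaps none beyond the scatter, is expected. Compound 3 is estimated at 15 nM, between 4 nM and 60 nM, a step of a 1.3-fold lower number from compound 2 to compound 3 (0.11 log units; within the scatter) that is expected rather than known.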

Compound 3, half-maximal inhibitory concentration: 322 nM
The estimate for compound 3 lay 21-fold (1.33 log units) below the measured number; the whole stated range lies below it.
By their numbers in this assay, from the lowest: compound 2; then compound 1; then compound 3.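

The aromatic carbon para to a large group in compound 2 is not a place where added size goes unnoticed: phenyl in place of hydrogen there gives a 17-fold higher number from compound 2 to compound 3 (1.22 log units; beyond the scatter) in this assay. At this position, then, adding this ring costs much of the inhibition. Going by these compounds, whether a smaller group on this carbon, such as methyl, fluorine or an amine, would keep the number close to that of compound 2 stays open, as does the effect of phenyl on another carbon of that ring. Nothing measured here explains the loss.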